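A few compounds are considered here, and "the series" means these few. Any claim that something is new, unique, unknown or untested is made for them only; others in the source may bear on it.

Measured compounds:
compound 1 `COc1ccc(C)cc1N1C(=O)CSC1c1cccc(C(=O)NCCCCc2ccccc2)c1` — 300 nM
compound 2 `COc1ccccc1N1C(=O)CSC1c1cccc(C(=O)NCCCCn2cncn2)c1` — > 1000 nM
compound 3 `Cc1ccnc(N2C(=O)CSC2c2cccc(C(=O)NCCCCn3cccn3)c2)c1` — 19.6 nM

In a functional assay on HOS-TE85 cells (Homo sapiens) for inhibition, read by CCK-8 assay, with a stated time of 72 h (on this read-out higher numbers stand for weaker inhibition and lower numbers for stronger inhibition), compound 1 gives 300 nM, the higher of the two numbers read. Compound 3 gives 19.6 nM, a gap from compound 1 that lies beyond the usual scatter. For compound 2 this assay returns only a limit, > 1000 nM, so no number stands for it; across the set, 1 of the 3 values sits at the limit of > 1000 nM in this assay, at which 1 of the 3 values shown sits. For the measured compounds named here, no pair among the three differs in a single place, so no measured step is available, and the effect of exchanging the group on the amide-type nitrogen in the ring cannot be separated from the changes at the amide end.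

Compound 4 `O=C(NCCCCc1ccccc1)c1cccc(C2SCC(=O)N2c2cccc(F)c2)c1` keeps the phenylbutyl amide of compound 1 and alters only the group on the ring nitrogen: 3-fluorophenyl in place of 2-methoxy-5-methylphenyl on an amide-type nitrogen in a ring.

Going by the values given here, with no measured step on this position, the change from compound 1 to compound 4 is expected to stay near the scatter: a 1.2-fold lower number from compound 1 to compound 4 (0.08 log units; within the scatter). Compound 4 is therefore expected to give about 250 nM in this assay, with a range from 60 nM to 1000 nM reflecting the absence of any comparable measured step.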

Compound 4, half-maximal inhibitory concentration: 32.4 nM
Compound 4: middle estimate off by 7.7-fold (0.89 log units), on the high side, outside the stated range (below it).
By their numbers in this assay, from the lowest: compounds 3 and 4 (each within the scatter of the next); then compound 1. At a limit, above all of these: compound 2.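

With the phenylbutyl amide held fixed, the group on the amide-type nitrogen in a ring now has a measured effect of its own in this assay: 3-fluorophenyl in place of 2-methoxy-5-methylphenyl gives a 9.3-fold lower number from compound 1 to compound 4 (0.97 log units; beyond the scatter). The earlier compounds shown here changed this group only together with the amide end, so they could not separate the two; this position alone now carries a step beyond the scatter. The step still bundles the loss of the methoxy and methyl groups with the arrival of fluorine, and no measurement at hand gives a cause for it.

Going by these compounds, it remains open which of these changes carries the step: a plain phenyl, a phenyl bearing only methoxy or only methyl, or a chlorophenyl on this nitrogen would begin to separate them. On these data alone, it is also open whether the same exchange gives a similar step with other amide ends, such as a shorter chain or a terminal carboxylic acid, since this single pair holds only the phenylbutyl amide constant.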